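A few compounds are considered here, and "the series" means these few. Any claim that something is new, unique, unknown or untested is made for them only; others in the source may bear on it.

Measured so far:
- compound 1 `C[C@H](NC(=O)Nc1cccc(C(F)(F)F)c1)c1ccccc1` gives 93% in an ADME assay on the whole organism with Oryza sativa as the target, tested at 1 uM; a higher number here means a weaker effect of the compound at the concentration tested, a lower number a stronger effect
- compound 2 `C[C@H](NC(=O)Nc1cccc(I)c1)c1ccccc1` gives 95% in this assay

Compound 1 stands at the lower of the two numbers, with compound 2 nearest: a number 2 percentage points higher from compound 1 to compound 2 (within the scatter). The two values therefore sit within the scatter of each other and neither can be called the stronger.

Compound 3 `C[C@H](NC(=O)Nc1cc(C(F)(F)F)ccc1F)c1ccccc1` differs from compound 1 by fluoro in place of hydrogen on an aromatic carbon. Within the data shown here, the only measured step, a number 2 percentage points higher from compound 1 to compound 2 (within the scatter), concerns an exchange of the trifluoromethyl for iodo and does not bear on an added fluoro; no step covers this change. Among the measured compounds shown here, with the single known step within the scatter and no bearing step, the step expected for compound 3 is set at none beyond the scatter, a number 1 percentage points lower from compound 1 to compound 3 (within the scatter). Compound 3 is therefore estimated at 92% in this assay, with a range from 82% to 100%.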

Compound 3, a percentage reported as activity, at one concentration (the size of the read-out at that concentration, not a potency): 89%
Compound 3: the middle estimate sits 3 percentage points above what was measured, and the stated range covers the measured number.
By their numbers in this assay, from the lowest: compounds 3, 1 and 2 (each within the scatter of the next).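

Fluoro in place of hydrogen on an aromatic carbon, ortho to a large group and para to a trifluoromethyl group, comes with a number 4 percentage points lower from compound 1 to compound 3 (within the scatter) in this assay. The earlier compounds shown here spoke only to the exchange of trifluoromethyl for iodo, whereas compound 3 adds a reading at a further place on the six-membered aromatic ring, and compound 1 and compound 3 cannot be told apart there. No measurement at hand gives a reason for this result.

On these data alone, the three compounds stand each within the scatter of the next, so it remains open whether any group on this ring can move the number beyond the scatter. Also open, as far as these compounds go, is what an amine, a carboxylic acid or a longer chain would give at this place.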